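Chloro for Methyl on the Benzyl Amide of Compound 3

The source may hold more compounds than are shown below. What is called first, only, known or untested is meant among the compounds shown, and "the series" means these compounds.

Compound 1 `C=CC1=C(C(=O)NCc2ccc(Cl)cc2)C(c2ccc(OC)cc2)OC1`: in a functional assay on A549 cells (Homo sapiens) for cytotoxicity, read by MTT assay, with a stated time of 24 h (on this read-out lower numbers stand for stronger inhibition and higher numbers for weaker inhibition), compound 1 gives only the assay limit, > 100000 nM.
Compound 2 `C=CC1=C(C(=O)NCCC)C(c2ccc(OC)c(OC)c2)OC1`: in this assay compound 2 likewise gives only a limit, > 100000 nM.
Compound 3 `C=CC1=C(C(=O)NCc2ccc(C)cc2)C(c2ccc(OC)c(OC)c2)OC1`: in this assay compound 3 also gives only a limit, > 100000 nM.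

Compound 3 thus stands at a limit rather than at a number, and the other two values are limits as well (the limit of > 100000 nM in this assay, at which 3 of the 3 values shown sit). The step that the two limits leave unreadable from compound 2 to compound 3 is therefore unreadable. Compound 4 `C=CC1=C(C(=O)NCc2ccc(Cl)cc2)C(c2ccc(OC)c(OC)c2)OC1` differs from compound 3 by chloro in place of methyl on an aromatic carbon. Within the data shown here, no measured step separates chloro from methyl on this ring, though compound 1 carries the same 4-chlorobenzyl amide on a related core and also sits at the limit. Compound 4 is therefore expected to remain at the limit, estimated at 100000 nM (30000 nM to 300000 nM), a step of a number no higher from compound 3 to compound 4 (the limit leaves the size open) expected to be none beyond the scatter.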

Compound 4, half-maximal inhibitory concentration: > 100000 nM
Compound 4 ended at the assay's limit; the forecaster's own chance of this, stated with the estimate: 85%; the middle value sits exactly at the limit.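

Compound 4 stands at a limit in this assay, and no step from compound 1, compound 2 or compound 3 to it can be read: the limit of > 100000 nM in this assay, at which 4 of the 4 values shown sit.

The compounds shown leave open whether any of these changes affects cytotoxicity at all.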